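A few compounds are considered here, and "the series" means these few. Any claim that something is new, unique, unknown or untested is made for them only; others in the source may bear on it.

Working notes on the series. Of the compounds shown here, two have numbers so far. Compound 2 `Nc1ccccc1NC(=O)c1ccc(Cn2cnc3c(Nc4ccc(-c5ccccn5)cc4)nc(Cl)nc32)cc1` stands highest of the two in a functional assay on HCT-116 cells (Homo sapiens) for antiproliferative activity, read by CCK-8 assay, with a stated time of 72 h, tested at 2 uM (on this read-out lower numbers stand for a weaker effect and higher numbers for a stronger effect at the one concentration tested), where compound 2 gives 69.5%. Compound 1 `Nc1ccccc1NC(=O)/C=C/c1ccc(Cn2cnc3c(Nc4cccc(Cl)c4)nc(Cl)nc32)cc1` is the nearest point, and in this assay compound 1 gives 12.9%, a gap beyond the scatter; the two are not a single-point pair, as compound 1 also differs in the link between the aromatic ring and the amide.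

Compound 3 `Nc1ccccc1NC(=O)c1ccc(Cn2cnc3c(Nc4cccc(Cl)c4)nc(Cl)nc32)cc1` is not yet measured. It differs from compound 2 in one place: 3-chlorophenyl in place of 4-(pyridin-2-yl)phenyl on a nitrogen on an aromatic ring. The 3-chlorophenyl is the group that compound 1 also carries, and compound 1 gives 12.9% in this assay. On that ground a drop beyond the scatter is expected, a number 34.5 percentage points lower from compound 2 to compound 3 (beyond the scatter), though part of the low number of compound 1 may belong to its other difference. The estimate for compound 3 in this assay is 35%, with a range from 10% to 62%.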

Compound 3, a percentage reported as inhibition, at one concentration (the size of the read-out at that concentration, not a potency): 56.2%
Compound 3: the middle estimate sits 21.2 percentage points below what was measured; the range from low to high includes it.
By their numbers in this assay, from the lowest: compound 1; then compound 3; then compound 2.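

In this assay, the group on the nitrogen on the aromatic ring now has its first single-point read: a number 13.3 percentage points lower from compound 2 to compound 3 (beyond the scatter), so activity is reduced but largely retained when 3-chlorophenyl replaces 4-(pyridin-2-yl)phenyl. The larger change lies elsewhere, with a number 43.3 percentage points higher from compound 1 to compound 3 (beyond the scatter) when (2-aminophenyl)carbamoyl replaces 2-((2-aminophenyl)carbamoyl)ethenyl on an aromatic carbon, so the 3-chlorophenyl group alone does not account for the low number of compound 1. Nothing measured on these compounds speaks to the origin of either step.

Open, going by these compounds, is how a plain phenyl or a 4-chlorophenyl on the same nitrogen would compare with compound 2 and compound 3. Also open, on these data alone, is what an amine in place of the chlorine on the shared core would do.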